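This account rests on a few compounds, and the source may have more. Where it says the series, first, only, none or still open, it means among the compounds named here.

Working notes on the diaryl ether urea series.

Compound 1, `O=C(Nc1ccccc1)Nc1ccc(Oc2ccc(-c3nccs3)cc2)cc1`, gives "not determined" (no result reported) in a functional assay on MDA-MB-231 cells (Homo sapiens) for inhibition, read by MTT assay and WST assay, with a stated time of 72 h, tested at 10 uM; on this read-out higher numbers stand for more inhibition of growth at the one concentration tested and lower numbers for less inhibition of growth. Compound 2, `O=C(Nc1ccc(Cl)cc1)Nc1ccc(Oc2ccc(-c3ncc[nH]3)cc2)cc1`, gives 47.6% in this assay. Compound 3, `O=C(Nc1ccccc1)Nc1ccc(Oc2ccc(-c3ncc[nH]3)cc2)cc1`, gives 11.4% in this assay. Among the compounds with values here, the single one-place step is a number 36.2 percentage points lower from compound 2 to compound 3 (beyond the scatter). On the two numbers at hand compound 3 therefore stands lowest, with compound 2 the nearest entry and well beyond the scatter above it; compound 1 contributes no number.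

Compound 4, `O=C(Nc1ccc(Oc2ccc(-c3ncc[nH]3)cc2)cc1)Nc1cc(C(F)(F)F)ccc1Cl`, differs from compound 3 by 2-chloro-5-(trifluoromethyl)phenyl in place of phenyl on an amide-type nitrogen. Within the data shown here, the only measured step that bears on this is the one from compound 2 to compound 3, in which loss of a chloro from the aromatic carbon of that terminal phenyl cost the large amount given by a number 36.2 percentage points lower from compound 2 to compound 3 (beyond the scatter). Among the measured compounds shown here, compound 4 restores a chloro on that ring and adds a trifluoromethyl; the data contain no step for the trifluoromethyl itself. A rise in this assay beyond the scatter is therefore expected, of roughly the size seen in the chloro step, though the added group leaves the range wide. On this basis the expected change is a number 33.6 percentage points higher from compound 3 to compound 4 (beyond the scatter). Compound 4 is estimated at 45%, with a range from 20% to 70%.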

Compound 4, percent growth inhibition at one concentration: 32.3%
Compound 4: middle estimate off by 12.7 percentage points, on the high side; the measured number falls inside the stated range.
By their numbers in this assay, from the lowest: compound 3; then compound 4; then compound 2.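

At the amide-type nitrogen, 2-chloro-5-(trifluoromethyl)phenyl in place of phenyl gives a number 20.9 percentage points higher from compound 3 to compound 4 (beyond the scatter) in this assay, so this position accepts a larger terminal ring carrying two substituents and still improves on plain phenyl. The same group in place of 4-chlorophenyl gives a number 15.3 percentage points lower from compound 2 to compound 4 (beyond the scatter), so among the three compounds with numbers, growth inhibition at this position does not simply rise as the terminal group gets larger or carries more substituents. Nothing at hand offers an explanation for either step.

Chloro and trifluoromethyl enter together in compound 4, and the chloro sits differently from the one in compound 2, so the contribution of each group and of the chloro's placement cannot be separated. Also open, as far as these compounds go, are how a terminal ring bearing trifluoromethyl alone, an amine or a carboxylic acid would behave at this position, and what the ring change in compound 1 does, as compound 1 has no number to compare.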